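The source may hold more compounds than are shown below. What is called first, only, known or untested is meant among the compounds shown, and "the series" means these compounds.

Of the compounds shown here, two of a shared core have been tested in a functional assay on DU-145 cells (Homo sapiens) for cytotoxicity, read by MTT assay, with a stated time of 48 h; a lower number here means a stronger inhibitor, a higher number a weaker inhibitor. Compound 2, `COc1ccc(-c2cc(C(=O)Nc3nc4ccc(F)cc4s3)nc3cc(-c4ccccc4)nn23)cc1`, gives 31400 nM in this assay. Compound 1, `COc1cc(-c2cc(C(=O)Nc3nc4ccc(Cl)cc4s3)nc3cc(-c4ccccc4)nn23)cc(OC)c1OC`, which already carries a 3,4,5-trimethoxyphenyl group, gives 38900 nM in this assay; the two numbers lie within the usual scatter of each other, so neither compound can be called the stronger inhibitor.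

Compound 3, `COc1cc(-c2cc(C(=O)Nc3nc4ccc(F)cc4s3)nc3cc(-c4ccccc4)nn23)cc(OC)c1OC`, has not yet been measured. It differs from compound 2 in one place: 3,4,5-trimethoxyphenyl in place of 4-methoxyphenyl on an aromatic carbon. Among the compounds with values here, no measured pair shows this change on its own, so its size is unknown. Since compound 1 carries the same 3,4,5-trimethoxyphenyl group and gives 38900 nM, a step no larger than the scatter is expected, in no particular direction, for a 1.1-fold higher number from compound 2 to compound 3 (0.05 log units; within the scatter). Compound 3 is therefore estimated at 35000 nM, with a range from 15000 nM to 80000 nM.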

Compound 3, half-maximal inhibitory concentration: 25700 nM
Compound 3: the middle estimate sits 1.4-fold (0.13 log units) above what was measured; the range from low to high includes it.
By their numbers in this assay, from the lowest: compounds 3, 2 and 1 (each within the scatter of the next).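

In this assay, placing 3,4,5-trimethoxyphenyl instead of 4-methoxyphenyl on this aromatic carbon, next to the ring nitrogen, gives a 1.2-fold lower number from compound 2 to compound 3 (0.09 log units; within the scatter), so a group of 12 heavy atoms in place of one of 8 leaves no change that can be told from the scatter. The second new comparison, fluoro in place of chloro with the 3,4,5-trimethoxyphenyl group kept, gives a 1.5-fold lower number from compound 1 to compound 3 (0.18 log units; within the scatter), so this halogen swap on the other side of the molecule cannot be told from the scatter either. Nothing available explains why either step is this small.

Still open, as far as these compounds go, is whether a quite different group on this aromatic carbon, such as an amine or a carboxylic acid, would move the number beyond the scatter. Also open, from the compounds shown here alone, is what a methoxy group or a plain hydrogen would do in place of the halogen.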